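Swapping 4-nitrophenyl for 3-chlorophenyl in compound 2

A few compounds are considered here, and "the series" means these few. Any claim that something is new, unique, unknown or untested is made for them only; others in the source may bear on it.

In a functional assay on UACC-62 cells (Homo sapiens) for cytotoxicity, read by sulforhodamine B assay (a higher number here means a weaker inhibitor of growth, a lower number a stronger inhibitor of growth), two compounds sharing one core have been measured so far. Compound 1 `CC1=CC[C@@H]([C@@](C)(O)CCCC(C)(C)NC(=S)N/N=C\c2ccc(C)cc2)CC1` gives 11600 nM and compound 2 `CC1=CC[C@@H]([C@@](C)(O)CCCC(C)(C)NC(=S)N/N=C\c2ccc([N+](=O)[O-])cc2)CC1` gives 20800 nM, so compound 2 stands level with compound 1 within the usual scatter. Compound 3 `CC1=CC[C@@H]([C@@](C)(O)CCCC(C)(C)NC(=S)N/N=C\c2cccc(Cl)c2)CC1` awaits measurement. In it, 3-chlorophenyl sits in place of 4-nitrophenyl on a carbon with a double bond to nitrogen (3-chlorophenyl in place of 4-nitrophenyl on a carbon with a double bond to nitrogen). For the measured compounds named here, only one measured step bears on this change. That step (a 1.8-fold higher number from compound 1 to compound 2 (0.25 log units; within the scatter)) put nitro in place of methyl on an aromatic carbon and stayed within the scatter. One small step is thin evidence, but it gives no reason to expect a move beyond the scatter in this assay here. An estimated 1.4-fold lower number from compound 2 to compound 3 (0.14 log units; within the scatter) is expected, which also stays within the scatter. Compound 3 is estimated at 15000 nM (expected range 7000 nM to 32000 nM).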

Compound 3, concentration for 50% growth inhibition: 7810 nM
Beside the measured number, compound 3's estimate is 1.9-fold (0.28 log units) above it; low and high end bracket the measured number.
By their numbers in this assay, from the lowest: compounds 3, 1 and 2 (each within the scatter of the next, the first and the last beyond it).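

In this assay, for the compounds shown here, the group on the carbon with a double bond to nitrogen can shift the result: a 2.7-fold lower number from compound 2 to compound 3 (0.43 log units; beyond the scatter) is the first step here to pass beyond the scatter, though only modestly. The other new comparison, a 1.5-fold lower number from compound 1 to compound 3 (0.17 log units; within the scatter), stays within the scatter, so 3-chlorophenyl and 4-methylphenyl cannot be told apart, and compound 1 sits within the scatter of both other compounds. No measurement shown accounts for the gap between 4-nitrophenyl and 3-chlorophenyl.

That step changes both the group on the aromatic ring and its place on the ring, and these compounds cannot separate the two. Also open, on these data alone, is how a ring carrying an amine or a carboxylic acid, or a plain phenyl ring with no added group, would fare at this position.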